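A few compounds are considered here, and "the series" means these few. Any claim that something is new, unique, unknown or untested is made for them only; others in the source may bear on it.

Measured so far in a functional assay on HT-29 cells (Homo sapiens) for cytotoxicity, read by MTT assay, with a stated time of 24 h, tested at 0.64 ug/mL; on this read-out higher numbers stand for a stronger effect at the one concentration tested and lower numbers for a weaker effect:

compound 1 `Cn1c(-c2ccc(NC(=O)CSc3nc4ccccc4o3)cc2)nc(-c2ccccc2)c1-c1ccccc1`: 24.8%
compound 2 `Cc1ccc2oc(SCC(=O)Nc3ccc(-c4nc(-c5ccccc5)c(-c5ccccc5)n4C)cc3)nc2c1`: 11%
compound 3 `Cn1c(-c2ccc(NC(=O)CN3CCN(Cc4ccccc4)CC3)cc2)nc(-c2ccccc2)c1-c1ccccc1`: 15.5%

The change methyl in place of hydrogen on an aromatic carbon gives a number 13.8 percentage points lower from compound 1 to compound 2 (beyond the scatter). Compound 3 stands against compound 1 and against compound 2 within the scatter, so no order among these three is read. The difference between the core of compound 3 and the core of compound 1 is not broken down here.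

Compound 4 `Cc1ccc(CN2CCN(CC(=O)Nc3ccc(-c4nc(-c5ccccc5)c(-c5ccccc5)n4C)cc3)CC2)cc1` is not yet measured. Its change from compound 3 is methyl in place of hydrogen on an aromatic carbon. This is the same kind of change as that from compound 1 to compound 2, not the same: in compound 2 the methyl sits on a ring that is part of a fused or bridged system of two rings, meta to a fused ring and para to a fused ring, whereas in compound 4 it sits on a six-membered aromatic ring of carbon only, para to a large group.

Beside the one measured step of a number 13.8 percentage points lower from compound 1 to compound 2 (beyond the scatter), the expected step is a number 6.5 percentage points lower from compound 3 to compound 4 (within the scatter), set smaller and with a wide range, as it rests on a single pair at a different place. For compound 4 the estimate in this assay is 9%, between 0% and 20%.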

Compound 4, a percentage reported as activity, at one concentration (the size of the read-out at that concentration, not a potency): 15.4%
Compound 4: middle estimate off by 6.4 percentage points, on the low side; the measured number falls inside the stated range.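

In this assay the change benzyl to 4-methylbenzyl gives a number 0.1 percentage points lower from compound 3 to compound 4 (within the scatter), so no effect of the methyl is read on this core. Set beside the earlier step, the two results for this change cannot be told apart: the same change on two cores in this assay, a number 13.8 percentage points lower (beyond the scatter) from compound 1 to compound 2 and a number 0.1 percentage points lower (within the scatter) from compound 3 to compound 4, 13.7 percentage points apart, within the scatter of two such steps. This does not show that the change carries from one core to the other, nor that it fails to, as each core offers a single pair, the methyl sits at a different place in each pair, and one step lies beyond the scatter while the other lies within it.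

The compounds shown leave open how a methoxy group, a chlorine atom or a carboxylic acid would read in place of the methyl of compound 4. Also open is whether a longer chain in place of that methyl, or an amine on the same ring, would give a step beyond the scatter, and the read-out at one concentration gives no potency for any of these compounds.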